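Methylamino for Butyl at the Far End of the Aryl Ring

The source may report more compounds than this note shows. Statements on the series, on what has been measured and on what is new or still open speak of the compounds shown alone.

Compound 1, `CC(C)c1ccc(-c2cc(Cl)cc(C(=O)Nc3nn[nH]n3)n2)cc1`, gives 14% in a functional assay on the whole organism for inhibition, with Rattus norvegicus as the target, at a dose of 1 mg/kg by the oral route; a lower number here means a weaker effect, a higher number a stronger effect of the compound at the dose given.
Compound 2, `COc1cc(C(=O)Nc2nn[nH]n2)nc(-c2ccc(OC)c(OC)c2)c1`, gives 18% in this assay.
Compound 3, `CCCCc1ccc(-c2cc(OC)cc(C(=O)Nc3nn[nH]n3)n2)cc1`, gives 29% in this assay.

Compound 3 holds the highest of the three numbers in this assay. The nearest to it is compound 2, whose number lies lower by a margin beyond the scatter, and compound 1 lies lower still, also beyond the scatter. The three measured compounds differ from one another in more than one place, so no single change among them has been isolated.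

Compound 4, `CNc1ccc(-c2cc(OC)cc(C(=O)Nc3nn[nH]n3)n2)cc1`, differs from compound 3 in one place: methylamino in place of butyl on an aromatic carbon. Among the compounds with values here, no measured pair shows this swap on its own, so there is no direct precedent for its effect. The step from compound 3 to compound 4 in this assay is expected to be small, a number 7 percentage points lower from compound 3 to compound 4 (within the scatter), most likely not beyond the scatter, with a slight lean downward since the other measured aryl substituents sit lower. Compound 4 is therefore estimated at 22%, within a range from 8% to 40%.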

Compound 4, a percentage reported as inhibition, in the whole organism at one dose (the size of the read-out at that dose, not a potency): 35%
For compound 4 the middle estimate is 13 percentage points below the measured one; low and high end bracket the measured number.
By their numbers in this assay, from the lowest: compounds 1 and 2 (each within the scatter of the next); then compounds 3 and 4 (each within the scatter of the next).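

Putting methylamino in place of butyl on this aromatic carbon, para to a large group, gives a number 6 percentage points higher from compound 3 to compound 4 (within the scatter) in this assay. As the only single-place step among these compounds, it shows that butyl, with 4 heavy atoms and no hydrogen-bond donor, can be exchanged for a group of 2 heavy atoms carrying a hydrogen-bond donor and acceptor without the read-out moving beyond the scatter. No measurement shown here explains this result.

Going by these compounds, whether this position stays as permissive for other groups remains open, since a primary amine, a dimethylamino group or a carboxylic acid on the same carbon would each test a different replacement. The read-out at one dose also leaves open how the two compounds would compare across a range of doses.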